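This account rests on a few compounds, and the source may have more. Where it says the series, first, only, none or still open, it means among the compounds named here.

Three related amides have been measured in an assay on HeLa cells for binding affinity to Vasopressin V2 receptor (Homo sapiens); on this read-out higher numbers stand for weaker inhibition and lower numbers for stronger inhibition. Compound 1 `CN(C)c1ccc(C(=O)N2CCCCc3ccccc32)c(Cl)c1` gives 18 nM, compound 2 `CCN(CC)c1ccc(C(=O)N2CCCCc3ccccc32)c(Cl)c1` gives 19 nM, and compound 3 `CN(C)c1ccc(C(=O)N2CCCCc3cc(Cl)ccc32)c(Cl)c1` gives 13 nM, the lowest of the three numbers, with both other values within the scatter of it. Compound 4 `CCNc1ccc(C(=O)N2CCCCc3cc(Cl)ccc32)c(Cl)c1` differs from compound 3 by ethylamino in place of dimethylamino on an aromatic carbon. For the measured compounds named here, two measured steps bear loosely on this. The step of a 1.1-fold higher number from compound 1 to compound 2 (0.02 log units; within the scatter) shows that a larger amino substituent hardly moves this assay, and a 1.4-fold lower number from compound 1 to compound 3 (0.14 log units; within the scatter) shows the same for an added chloro. Neither step replaces dimethylamino with ethylamino, so the guidance is indirect. Compound 4 is therefore expected to give 18 nM, between 7 nM and 50 nM. That expectation means a step of a 1.4-fold higher number from compound 3 to compound 4 (0.14 log units; within the scatter), within the scatter.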

Compound 4, half-maximal inhibitory concentration: 5 nM
Estimate against measurement, compound 4: 3.6-fold (0.56 log units) above, outside the stated range (below it).
By their numbers in this assay, from the lowest: compound 4; then compounds 3, 1 and 2 (each within the scatter of the next).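

In this assay, for the compounds shown here, ethylamino in place of dimethylamino on this aromatic carbon brings a 2.6-fold lower number from compound 3 to compound 4 (0.41 log units; beyond the scatter) and is the only step so far beyond the scatter. The heavy atoms stay the same in number and kind, but ethylamino carries one hydrogen-bond donor and dimethylamino none, so this position distinguishes two groups of equal size in a way the step to diethylamino did not show. No measurement shown explains this difference.

Methylamino or a plain amino group here would help separate the role of the amide-free amino hydrogen from that of the ethyl chain. On these data alone, whether the change holds without the added chloro remains open.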